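A few compounds are considered here, and "the series" means these few. Any claim that something is new, unique, unknown or untested is made for them only; others in the source may bear on it.

Measured so far:
compound 1 `CNC(=O)c1ccc(Oc2cccc(NC(=S)Nc3ccc(Cl)cc3)c2)nc1` — 28400 nM in a functional assay on PC-3 cells (Homo sapiens) for antiproliferative activity, read by MTT assay; a lower number here means a stronger inhibitor, a higher number a weaker inhibitor
compound 2 `CNC(=O)c1ccc(Oc2cccc(NC(=S)Nc3ccc(OC)cc3)c2)nc1` — > 100000 nM in this assay
compound 3 `CNC(=O)c1ccc(Oc2cccc(NC(=S)Nc3ccc(F)c(Cl)c3)c2)nc1` — not yet measured

Compound 2 stands at the weak end of the two numbers shown. In this assay compound 2 gives only > 100000 nM; this is a limit of the assay, not a number (the limit of > 100000 nM in this assay, at which 1 of the 2 values shown sits). Among the compounds with values here, compound 1, the only other measured compound, gives 28400 nM in this assay, and the step of an at least 3.5-fold higher number from compound 1 to compound 2 (0.54 log units; beyond the scatter) is the only measured step.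

Compound 3 differs from compound 2 by 3-chloro-4-fluorophenyl in place of 4-methoxyphenyl on an amide-type nitrogen. The step of an at least 3.5-fold higher number from compound 1 to compound 2 (0.54 log units; beyond the scatter) bears directly on it, since it runs the same exchange in the opposite direction: chloro back in place of methoxy, here with a fluoro beside it on the ring. A step of at least that size is therefore expected to return, towards stronger inhibition, as an at least 4.5-fold lower number from compound 2 to compound 3 (0.65 log units; beyond the scatter). Compound 3 is estimated at 22000 nM in this assay, with a range from 6000 nM to 80000 nM.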

Compound 3, half-maximal inhibitory concentration: 18400 nM
The estimate for compound 3 lay 1.2-fold (0.08 log units) above the measured number; the measured number falls inside the stated range.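

In this assay, 3-chloro-4-fluorophenyl in place of 4-methoxyphenyl on the amide-type nitrogen gives an at least 5.4-fold lower number from compound 2 to compound 3 (0.73 log units; beyond the scatter), so 4-chlorophenyl is no longer the only ring shown to stand clear of 4-methoxyphenyl. Compound 2 is held only by a limit of the assay, so this step has a floor and no exact size: the limit of > 100000 nM in this assay, at which 1 of the 3 values shown sits. The second exchange, 3-chloro-4-fluorophenyl in place of 4-chlorophenyl, gives a 1.5-fold lower number from compound 1 to compound 3 (0.19 log units; within the scatter), so the two halogen-bearing rings cannot be told apart at this position.

From the compounds shown here alone, whether the gap comes from losing the methoxy or from gaining a halogen stays open, since the series holds no plain phenyl for comparison. Also open, going by these compounds, is how a 4-trifluoromethylphenyl or a 4-aminophenyl on this nitrogen would read in this assay.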